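From dimethylamino to benzyl(methyl)amino on the shared core

The compounds below may be only part of what the source reports. "The series", "measured", "known", "first", "only" and "open" are said of these compounds alone.

Measured in a functional assay on PC-3 cells (Homo sapiens) for cytotoxicity, read by XTT assay, with a stated time of 72 h; a higher number here means a weaker inhibitor, a lower number a stronger inhibitor:
- compound 1 `CCCN(C)C(=O)c1ccc(-c2cc(-c3cc(OC)ccc3OC)no2)s1`: > 30000 nM (a limit)
- compound 2 `COc1ccc(OC)c(-c2cc(-c3ccc(C(=O)N4CCCC4)s3)on2)c1`: > 30000 nM (a limit)
- compound 3 `COc1ccc(OC)c(-c2cc(-c3ccc(C(=O)N(C)C)s3)on2)c1`: > 30000 nM (a limit)

Compound 3 stands only at a limit, > 30000 nM. It has company there: the limit of > 30000 nM in this assay, at which 3 of the 3 values shown sit.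

Compound 4 `COc1ccc(OC)c(-c2cc(-c3ccc(C(=O)N(C)Cc4ccccc4)s3)on2)c1` carries phenyl in place of hydrogen on a saturated chain carbon bound to an amide-type nitrogen. In words, this is phenyl in place of hydrogen on a saturated chain carbon bound to an amide-type nitrogen, or methyl to benzyl.

The nearest measured change at this place is a step that the two limits leave unreadable from compound 1 to compound 3. Two changes on the carbonyl carbon also bear on it: a step that the two limits leave unreadable from compound 1 to compound 2 and a step that the two limits leave unreadable from compound 2 to compound 3. None of these has a readable size, and none gives a direction. Within the data shown here, no compound measured so far carries a phenyl at this place. The working expectation is therefore that nothing moves in this assay, though a gain cannot be excluded.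

The expected change is a number no higher from compound 3 to compound 4 (the limit leaves the size open).

Compound 4 is estimated at 30000 nM, with an expected range of 10000 nM to 50000 nM.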

Compound 4, half-maximal inhibitory concentration: > 30000 nM
Compound 4: a limit, no number (the forecaster's own chance of this, stated with the estimate: 70%); the middle value sits exactly at the limit.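

Among these compounds, compound 4 stands at a limit in this assay, as do compound 1, compound 2 and compound 3, so no step among them can be read. The compounds shown leave open whether any change on the shared core would give a readable number: the limit of > 30000 nM in this assay, at which 4 of the 4 values shown sit.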